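From isopentyloxy to isobutoxy: a small expected step

The source may hold more compounds than are shown below. What is called first, only, known or untested is meant among the compounds shown, and "the series" means these compounds.

In a functional assay on HCT-8 cells (Homo sapiens) for antiproliferative activity, read by sulforhodamine B assay, with a stated time of 3 days (on this read-out higher numbers stand for an effect only at larger amounts of compound and lower numbers for an effect already at smaller amounts), compound 1 (`CCCC1=C(OC)C(CCC)(CCC)C(=O)/C(=C(O)\C=C\c2ccccc2)C1=O`) gives 3.5 uM and compound 2 (`CCCC1=C(OC)C(CCC)(CCC)C(=O)/C(=C(O)\C=C\c2ccc(I)cc2)C1=O`) gives 1.1 uM. Compound 3 (`CCCC1=C(OCCC(C)C)C(CCC)(CCC)C(=O)/C(=C(O)\C=C\c2ccccc2)C1=O`) gives 15.3 uM, the highest of the three numbers. Compound 4 (`CCCC1=C(OCC(C)C)C(CCC)(CCC)C(=O)/C(=C(O)\C=C\c2ccccc2)C1=O`) carries isopropyl in place of isobutyl on a saturated chain carbon bound to an oxygen on an unsaturated carbon. The step that bears on this change sits at that same place, where isobutyl replacing hydrogen gives a 4.4-fold higher number from compound 1 to compound 3 (0.64 log units; beyond the scatter). The iodo step, a 3.2-fold lower number from compound 1 to compound 2 (0.50 log units; beyond the scatter), lies on an aromatic carbon and bears on it little. Removing part of the chain should undo only part of the isobutyl step, so a small move to a lower number is expected, estimated as a 1.7-fold lower number from compound 3 to compound 4 (0.23 log units; within the scatter). For compound 4 the estimated value is 9 uM, with an expected range of 4 uM to 18 uM.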

Compound 4, concentration for half-maximal effect: 8 uM
Compound 4: the middle estimate sits 1.1-fold (0.05 log units) above what was measured; measured number inside the range.
By their numbers in this assay, from the lowest: compound 2; then compound 1; then compounds 4 and 3 (each within the scatter of the next).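

In this assay, isopropyl in place of isobutyl at this saturated chain carbon gives a 1.9-fold lower number from compound 3 to compound 4 (0.28 log units; within the scatter), so isopentyloxy and isobutoxy cannot be told apart here. Isopropyl in place of hydrogen at the same carbon still gives a 2.3-fold higher number from compound 1 to compound 4 (0.36 log units; beyond the scatter), so the shorter chain does not fully undo the isobutyl step. No evidence shown accounts for either step. Open, on these data alone, is how an amine or a carboxylic acid in place of isopropyl at this place would read, and whether the iodo step holds with isobutoxy or isopentyloxy.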